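The source may hold more compounds than are shown below. What is called first, only, known or untested is meant among the compounds shown, and "the series" means these compounds.

Compound 1 `C=CC(=O)Nc1cc(Nc2ncc3ncn(-c4ccccc4)c3n2)c(OC)cc1N(C)CCN(C)C`; in an ADME assay on HT-29 cells (Homo sapiens) for cytotoxicity, read by MTT assay, with a stated time of 72 h (a lower number here means a stronger inhibitor, a higher number a weaker inhibitor), compound 1 gives 8080 nM.
Compound 2 `C=CC(=O)Nc1cc(Nc2ncc3ncn(-c4ccccc4Br)c3n2)c(OC)cc1N(C)CCN(C)C`; in this assay compound 2 gives 16200 nM.

Compound 2 holds the higher of the two numbers, but the step of a 2.0-fold higher number from compound 1 to compound 2 (0.30 log units; within the scatter) is within the scatter, so neither compound can be called the stronger. Compound 3 `C=CC(=O)Nc1cc(Nc2ncc3ncn(C4CCCC4)c3n2)c(OC)cc1N(C)CCN(C)C` differs from compound 2 by cyclopentyl in place of 2-bromophenyl on an aromatic nitrogen. Within the data shown here, no measured step touches this ring nitrogen with a change of this kind; the only step known, from a hydrogen to a bromo, was small. Compound 3 is therefore expected to sit near compound 2, with the step of a 1.4-fold lower number from compound 2 to compound 3 (0.13 log units; within the scatter) expected to lie within the scatter. The estimate for compound 3 in this assay is 12000 nM, between 3500 nM and 40000 nM.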

Compound 3, half-maximal inhibitory concentration: 20900 nM
Estimate against measurement, compound 3: 1.7-fold (0.24 log units) below, within the range that was stated.
By their numbers in this assay, from the lowest: compounds 1, 2 and 3 (each within the scatter of the next, the first and the last beyond it).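

Changing the group on the aromatic nitrogen can move the number beyond the scatter: in this assay cyclopentyl in place of phenyl gives a 2.6-fold higher number from compound 1 to compound 3 (0.41 log units; beyond the scatter) and is the only step among these compounds to do so. Cyclopentyl in place of 2-bromophenyl gives a 1.3-fold higher number from compound 2 to compound 3 (0.11 log units; within the scatter) and stays within the scatter, so in these three compounds the reading depends on which aromatic group leaves.

Whether an amine or a longer chain on this nitrogen would shift the number remains open, and no evidence given here explains either step.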